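Replacing a difluoroethyl amide with a chloropyrimidine carbonyl

The source may report more compounds than this note shows. Statements on the series, on what has been measured and on what is new or still open speak of the compounds shown alone.

Compound 1, `Cc1nc(S(C)(=O)=O)ccc1Oc1ncnc(OC2CCN(C(=O)OC(C)(C)C(F)(F)F)CC2)c1F`, gives 79% in a functional assay on isolated protein for inhibition of Glucose-dependent insulinotropic receptor (Rattus norvegicus), read by HTRF and cAMP accumulation; a higher number here means a larger maximal response, a lower number a smaller maximal response.
Compound 2, `Cc1nc(S(C)(=O)=O)ccc1Oc1ncnc(OC2CCN(C(=O)C(F)(F)F)CC2)c1F`, gives 76% in this assay.
Compound 3, `Cc1nc(S(C)(=O)=O)ccc1Oc1ncnc(OC2CCN(C(=O)C(C)(F)F)CC2)c1F`, gives 87% in this assay.

Compound 3 holds the highest of the three numbers, though its gap to compound 1 lies within the scatter and only its gap to compound 2 lies beyond it. The three measured compounds share a core and differ only in the group on the carbonyl carbon of the ring amide. Compound 4, `Cc1nc(S(C)(=O)=O)ccc1Oc1ncnc(OC2CCN(C(=O)c3ncc(Cl)cn3)CC2)c1F`, carries 5-chloropyrimidin-2-yl in place of 1,1-difluoroethyl on a carbonyl carbon. The measured steps on this same carbonyl carbon were a number 3 percentage points lower from compound 1 to compound 2 (within the scatter), a number 8 percentage points higher from compound 1 to compound 3 (within the scatter) and a number 11 percentage points higher from compound 2 to compound 3 (beyond the scatter); none of them moved the response far, and none brought in a ring. Among the measured compounds shown here, there is thus no direct precedent for an aromatic group on this carbonyl carbon, only the observation that three rather different groups there gave similar maximal responses. Compound 4 is therefore expected to stay close to the band of the measured compounds, with no step beyond the scatter in this assay, estimated as a number 7 percentage points lower from compound 3 to compound 4 (within the scatter). For compound 4 the expected value is 80%, with a range from 62% to 95%.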

Compound 4, largest response reached (reported as efficacy), in percent of the reference or control that the assay uses: 77%
Compound 4: the middle estimate sits 3 percentage points above what was measured; the measured number falls inside the stated range.
By their numbers in this assay, from the lowest: compounds 2, 4, 1 and 3 (each within the scatter of the next, the first and the last beyond it).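

A ring can sit on this carbonyl carbon: with 5-chloropyrimidin-2-yl there, this assay gives a number 10 percentage points lower from compound 3 to compound 4 (within the scatter) and a number 1 percentage points higher from compound 2 to compound 4 (within the scatter) and also a number 2 percentage points lower from compound 1 to compound 4 (within the scatter) and thus stays in the band of the three earlier groups. Even a six-membered aromatic ring bringing hydrogen-bond acceptors to a place that previously held none therefore produces no step beyond the scatter from compound 1 or compound 2 or compound 3. Nothing available here accounts for this tolerance.

From the compounds shown here alone, it remains open whether phenyl, an unsubstituted pyrimidin-2-yl or a simple amine on this carbonyl carbon would stay within the same band. Going by these compounds, it is also open whether the chlorine of compound 4 contributes anything to the response, or whether any group here could take the response well outside this band.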